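The source may report more compounds than this note shows. Statements on the series, on what has been measured and on what is new or still open speak of the compounds shown alone.

Measured compounds:
compound 1 `CCc1ccc(-c2nn3cc(-c4cccc(N)c4)nc3s2)cc1` — 8100 nM
compound 2 `C=C(Br)C(=O)Nc1cccc(-c2cn3nc(Cc4cccc(OC)c4)sc3n2)c1` — 2500 nM
compound 3 `Nc1cccc(-c2cn3nc(CCc4ccccc4)sc3n2)c1` — 242000 nM

All three numbers come from a functional assay on HeLa cells (Homo sapiens) for inhibition, read by cell counting, with a stated time of 4 days; a lower number here means a stronger inhibitor, a higher number a weaker inhibitor. Compound 2 gives the lowest number of the three; in this assay compound 1 and compound 3 both lie beyond the usual scatter from it, so compound 2 counts as the strongest inhibitor among these. Compound 3 gives by far the highest number of the set.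

Compound 4 `C=C(Br)C(=O)Nc1cccc(-c2cn3nc(Cc4ccc(Cl)cc4)sc3n2)c1` is not yet measured. Relative to compound 2 the change is 4-chlorophenyl in place of 3-methoxyphenyl on a saturated chain carbon bound to an aromatic carbon. Among the compounds with values here, no pair of measured compounds differs only at this position, so nothing here shows how a change at the saturated chain carbon bound to an aromatic carbon moves the number; the amide on the other side of the shared core stays as in compound 2. The step from compound 2 to compound 4 is therefore expected to be small, a 1.2-fold higher number from compound 2 to compound 4 (0.08 log units; within the scatter), with no clear direction beyond the scatter. For compound 4 in this assay the estimate is 3000 nM, within a range of 900 nM to 10000 nM.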

Compound 4, half-maximal inhibitory concentration: 2700 nM
Estimate against measurement, compound 4: 1.1-fold (0.05 log units) above, within the range that was stated.
By their numbers in this assay, from the lowest: compounds 2 and 4 (each within the scatter of the next); then compound 1; then compound 3.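

In this assay, within the data shown here, this is the first one-place comparison at the saturated chain carbon bound to an aromatic carbon: 4-chlorophenyl in place of 3-methoxyphenyl gives a 1.1-fold higher number from compound 2 to compound 4 (0.03 log units; within the scatter) and so does not separate the two compounds. With the amide on the other side of the shared core held constant, this one exchange shows that 3-methoxybenzyl and 4-chlorobenzyl are interchangeable in this read-out, which says nothing yet about other groups at this place. No measurement is available that would account for this result.

Still open, as far as these compounds go, is whether the substituent or its place on the ring matters, a question that 3-chlorobenzyl and 4-methoxybenzyl could separate. Also open, from the compounds shown here alone, is how an amine or a carboxylic acid on this ring would read in this assay.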